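Methyl for acetyl on the aromatic oxygen of compound 2

A few compounds are considered here, and "the series" means these few. Any claim that something is new, unique, unknown or untested is made for them only; others in the source may bear on it.

Compound 2 `CCc1cccc2c(OC(C)=O)c(-c3occ(C)c3COC(C)=O)ccc12` was examined in a functional assay on ZR-75-1 cells (Homo sapiens) for cytotoxicity, read by MTT assay, with a stated time of 72 h; a lower number here means that less compound is needed, a higher number that more compound is needed for the effect. In this assay compound 2 gives > 10 ug/mL, which is a limit of the assay rather than a number. Among the measured compounds shown here, compound 1 `CCc1cccc2c(OC)c(-c3occ(C)c3CO)ccc12` is the only other measured compound. In this assay compound 1 gives > 10 ug/mL, again a limit of the assay. Compound 2 thus stands at the limit of > 10 ug/mL in this assay, at which 2 of the 2 values shown sit, alongside compound 1, and the numbers shown separate nothing between the two. Compound 3 `CCc1cccc2c(OC)c(-c3occ(C)c3COC(C)=O)ccc12` has not yet been measured. It differs from compound 2 in one place: methyl in place of acetyl on an oxygen on an aromatic ring. For the measured compounds named here, no measured step between two compounds is available to size this change. Both known values sit at the limit of > 10 ug/mL in this assay, at which 2 of the 2 values shown sit. The step expected in this assay is therefore none beyond the scatter, a step that the limit leaves unreadable from compound 2 to compound 3. For compound 3 the estimate in this assay is 15 ug/mL, in the range 7 ug/mL to 40 ug/mL, most probably reported again only as a limit.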

Compound 3, concentration for half-maximal effect: 3.5 ug/mL
The estimate for compound 3 lay 4.3-fold (0.63 log units) above the measured number; measured number outside the range, below it.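

In this assay, among the compounds shown here, compound 3 is the first compound to give a number rather than a limit, so both places on the shared core can now be read. On the oxygen on an aromatic ring, the change from acetoxy to methoxy gives an at least 2.8-fold lower number from compound 2 to compound 3 (0.45 log units; beyond the scatter). On the oxygen on a saturated carbon, acetyl in place of hydrogen gives an at least 2.8-fold lower number from compound 1 to compound 3 (0.45 log units; beyond the scatter), so neither free hydroxyl there nor acetoxy on the aromatic ring goes with a number in the compounds shown.

Going by these compounds, the full size of each step stays open, since only a lower bound can be read: the limit of > 10 ug/mL in this assay, at which 2 of the 3 values shown sit. Also open, on these data alone, is whether a longer chain such as butyryl, or an amine, on the oxygen on a saturated carbon would keep, lower or raise the number.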